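This account rests on a few compounds, and the source may have more. Where it says the series, first, only, none or still open, it means among the compounds named here.

Compound 1 `CCOC(=O)c1oc2ccc(NS(=O)(=O)c3ccccc3C)cc2c1C` and compound 2 `CCOC(=O)c1oc2ccc(NS(=O)(=O)c3ccccc3C(F)(F)F)cc2c1C` share one core and differ only in the group on an aromatic carbon of a six-membered aromatic ring of carbon only, ortho to a large group. In a functional assay on MDA-MB-231 cells (Homo sapiens) for antiproliferative activity, read by MTT assay, with a stated time of 72 h (on this read-out higher numbers stand for weaker inhibition and lower numbers for stronger inhibition), compound 1 gives 89200 nM, while compound 2 gives 82400 nM. The exchange of methyl for trifluoromethyl amounted to a 1.1-fold lower number from compound 1 to compound 2 (0.03 log units; within the scatter), so compound 2 holds the lowest of the two numbers, with compound 1 nearest and not separable from it.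

Compound 3 `CCOC(=O)c1oc2ccc(NS(=O)(=O)c3ccccc3[N+](=O)[O-])cc2c1C` varies the same carbon once more: nitro in place of trifluoromethyl on an aromatic carbon. Among the compounds with values here, only one measured step bears on this position, namely a 1.1-fold lower number from compound 1 to compound 2 (0.03 log units; within the scatter), and it did not move the readout beyond the scatter. Within the data shown here, no other step tells how the shared core responds to a change at this carbon. On that evidence no step beyond the scatter is expected in this assay in either direction, and compound 3 is estimated at 80000 nM, with a range from 40000 nM to 160000 nM. The change so expected from compound 2 to compound 3 is a 1.0-fold lower number from compound 2 to compound 3 (0.01 log units; within the scatter).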

Compound 3, half-maximal inhibitory concentration: 80400 nM
The estimate for compound 3 lay 1.0-fold (0.00 log units) below the measured number; the measured number falls inside the stated range.
By their numbers in this assay, from the lowest: compounds 3, 2 and 1 (each within the scatter of the next).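

In this assay, the exchange of trifluoromethyl for nitro gave a 1.0-fold lower number from compound 2 to compound 3 (0.01 log units; within the scatter) and the exchange of methyl for nitro gave a 1.1-fold lower number from compound 1 to compound 3 (0.05 log units; within the scatter) so the flat result no longer rests on a single exchange. Within the data shown here, this carbon has now carried three groups, methyl, trifluoromethyl and nitro, and no pair among them can be separated on this read-out. Nitro also brings 2 hydrogen-bond acceptors and a double bond outside aromatic rings, where trifluoromethyl has neither, and even that difference in what is counted goes with no step beyond the scatter, while nothing available accounts for this outcome.

The three compounds leave open whether an amine, a carboxylic acid or a longer chain such as propyl on this same carbon would move the number beyond the scatter, as all three groups tested here leave it in one place. They also leave open whether this carbon would stay as unresponsive if the shared core were changed elsewhere, for instance with a carboxylic acid in place of the ethyl ester.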